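The source may report more compounds than this note shows. Statements on the series, on what has been measured and on what is new or still open speak of the compounds shown alone.

Three related compounds have a reading so far in a physicochemical assay for solubility, measured as kinetic solubility; a lower number here means a less soluble compound, a higher number a more soluble compound. Compound 1 (`Cc1cnc(NC(=O)c2cc(Oc3cnc(C(=O)N(C)C)nc3)c3cc(C)oc3c2)cn1`) gives 463000 nM as the highest number of the three. Compound 2 (`Cc1cnc(NC(=O)c2cc(Oc3cnc(C(=O)N4CCCCC4)cn3)c3cc(C)oc3c2)cn1`) gives 24000 nM as the lowest. Compound 3 (`COC1CN(C(=O)c2cnc(Oc3cc(C(=O)Nc4cnccn4)cc4oc(C)cc34)cn2)C1`) gives 158000 nM and so stands second highest, with its gaps to both of the others beyond the usual scatter.

Compound 4 (`Cc1cc2c(Oc3cnc(C(=O)N(C)C)cn3)cc(C(=O)Nc3cnccn3)cc2o1`) has not been measured yet. It differs from compound 3 in one place (dimethylamino in place of 3-methoxyazetidin-1-yl on a carbonyl carbon): dimethylamino in place of 3-methoxyazetidin-1-yl on a carbonyl carbon. Among the measured compounds shown here, no two measured compounds differ in one place only, so the data offer no direct precedent for this change. For the measured compounds named here, the one loose pointer is compound 1, which also has dimethylamino on a carbonyl carbon and gives 463000 nM at the top of the three. It also differs from compound 3 elsewhere, so this pointer carries little weight. A modest rise is therefore expected, possibly no larger than the scatter. The expected move (a 1.5-fold higher number from compound 3 to compound 4 (0.18 log units; within the scatter)) is upward and small. For compound 4 the estimated value is 240000 nM (expected range 90000 nM to 550000 nM).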

Compound 4, solubility: 30000 nM
Estimate against measurement, compound 4: 8.0-fold (0.90 log units) above; measured number outside the range, below it.
By their numbers in this assay, from the lowest: compounds 2 and 4 (each within the scatter of the next); then compound 3; then compound 1.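

In this assay, among the compounds shown here, replacing 3-methoxyazetidin-1-yl with dimethylamino on a carbonyl carbon gives a 5.3-fold lower number from compound 3 to compound 4 (0.72 log units; beyond the scatter) and is the first change seen in isolation, with the rest of the molecule held the same. This shows that the group on this carbonyl carbon can by itself shift the reading beyond the usual scatter, so this position is not a silent one in this pair. The group that enters is also the smaller one, with no ring and fewer heavy atoms, yet it carries the lower number, although a single pair cannot establish a general trend.

The compounds shown leave open whether the higher number of compound 3 goes with the four-membered ring, with its methoxy group or with both, a question that a plain azetidine or a morpholine on the same carbonyl carbon would help to narrow. Nothing given here measures why this change lowers the number, so the step stands as an observation without an explanation.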